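Isobutylsulfanyl to cyclohexylsulfanyl: compound 3 to compound 4

This account rests on a few compounds, and the source may have more. Where it says the series, first, only, none or still open, it means among the compounds named here.

Values from an ADME assay on cells (Fibroblast, Gallus gallus) for cytotoxicity, read by CCK-8 assay, with a stated time of 48 h (a higher number here means that more compound is tolerated, a lower number that less compound is tolerated), follow, each of them a limit and not a number
Compound 1 `CCc1ccc(CN[C@H]2CC(C(=O)O)=C[C@@H](OC(CC)CC)[C@@H]2NC(C)=O)cc1` gives > 200000 nM as a limit
Compound 2 `CCC(CC)O[C@@H]1C=C(C(=O)O)C[C@H](NCc2ccc(Oc3ccccc3)cc2)[C@H]1NC(C)=O` gives > 200000 nM as a limit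
Compound 3 `CCC(CC)O[C@@H]1C=C(C(=O)O)C[C@H](NCc2ccc(SCC(C)C)cc2)[C@H]1NC(C)=O` gives > 200000 nM as a limit

The series stands at the limit of > 200000 nM in this assay, at which 3 of the 3 values shown sit, and compound 3 is part of it, with no number of its own. Compound 4 `CCC(CC)O[C@@H]1C=C(C(=O)O)C[C@H](NCc2ccc(SC3CCCCC3)cc2)[C@H]1NC(C)=O` carries cyclohexyl in place of isobutyl on a sulfur and is otherwise the same. The measured steps that bear on this change are a step that the two limits leave unreadable from compound 1 to compound 3 and a step that the two limits leave unreadable from compound 2 to compound 3 and neither offers a size. No direction is therefore expected in this assay and no step beyond the scatter. The expected step is a number no higher from compound 3 to compound 4 (the limit leaves the size open) with neither direction favoured. Compound 4 is estimated at 200000 nM with an expected range of 100000 nM to 400000 nM and may well report only a limit.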

Compound 4, half-maximal cytotoxic concentration: > 200000 nM
Compound 4: only a limit was reported (the forecaster's own chance of this, stated with the estimate: 85%); the middle value sits exactly at the limit.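

No new step can be read in this assay between compound 4 and compounds 1, 2 and 3, because each value is only a limit: the limit of > 200000 nM in this assay, at which 4 of the 4 values shown sit.

The compounds shown leave open whether any of these groups changes this read-out at all.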